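Pyridin-4-yl Replaces Isopropyl on a Carbonyl Carbon

The source may hold more compounds than are shown below. What is called first, only, known or untested is meant among the compounds shown, and "the series" means these compounds.

Compound 1 `O=C(Cn1ccnc1)N1CCC(NS(=O)(=O)c2cc(S(=O)(=O)c3ccccc3)ccc2C(F)(F)F)CC1`: 230 nM
Compound 2 `O=C1CC[C@@H](C(=O)N2CCC(NS(=O)(=O)c3cc(S(=O)(=O)c4ccccc4)ccc3C(F)(F)F)CC2)N1`: 240 nM
Compound 3 `CC(C)C(=O)N1CCC[C@H]1C(=O)N1CCC(NS(=O)(=O)c2cc(S(=O)(=O)c3ccccc3)ccc2C(F)(F)F)CC1`: 90 nM

In a functional assay on U2OS cells for antagonist activity at proto-oncogene Wnt-3 (Homo sapiens), read by a luciferase reporter, with a stated time of 18 h (on this read-out lower numbers stand for an effect already at smaller amounts and higher numbers for an effect only at larger amounts of compound), compound 3 gives the lowest number of the three: the steps of a 2.6-fold lower number from compound 1 to compound 3 (0.41 log units; beyond the scatter) and a 2.7-fold lower number from compound 2 to compound 3 (0.43 log units; beyond the scatter) both lie beyond the scatter, while a 1.0-fold higher number from compound 1 to compound 2 (0.02 log units; within the scatter) does not. Compound 4 `O=C([C@@H]1CCCN1C(=O)c1ccncc1)N1CCC(NS(=O)(=O)c2cc(S(=O)(=O)c3ccccc3)ccc2C(F)(F)F)CC1` differs from compound 3 by pyridin-4-yl in place of isopropyl on a carbonyl carbon. Going by the values given here, no measured step changes this group; the known steps alter the whole unit on the neighbouring carbonyl and were modest in size, so a comparable, modest change in either direction or none beyond the scatter seems plausible. Compound 4 is therefore expected to give about 100 nM, between 35 nM and 300 nM, the change from compound 3 being estimated as a 1.1-fold higher number from compound 3 to compound 4 (0.05 log units; within the scatter).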

Compound 4, half-maximal effective concentration: 350 nM
For compound 4 the middle estimate is 3.5-fold (0.54 log units) below the measured one; the measured number lies above the stated range.
By their numbers in this assay, from the lowest: compound 3; then compounds 1, 2 and 4 (each within the scatter of the next).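

In this assay the change of isopropyl to pyridin-4-yl, a 3.9-fold higher number from compound 3 to compound 4 (0.59 log units; beyond the scatter), shows that this position is not indifferent to what sits on the carbonyl carbon. The earlier steps shown here replaced the whole unit on the neighbouring carbonyl, whereas this one changes only the isopropyl group, and that alone moves the number beyond the scatter. No measurement available here accounts for the shift. Still open, going by these compounds, is whether the ring or its nitrogen matters; a phenyl group, the same ring without that nitrogen, would separate the two.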